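Notes on a small triazole series: chloro to methyl swap

This account rests on a few compounds, and the source may have more. Where it says the series, first, only, none or still open, it means among the compounds named here.

Measured compounds in an assay on isolated protein for inhibition of Aromatase (Homo sapiens), read by fluorescence and colorimetric assay, with a stated time of 30 min; a lower number here means a stronger inhibitor, a higher number a weaker inhibitor:
Compound 1 `CCCCCCCCCCc1cn(C(c2ccccc2)c2ccccc2)nn1` gives 13500 nM.
Compound 2 `c1ccc(OCc2cn(C(c3ccccc3)c3ccccc3)nn2)cc1` gives 31300 nM.
Compound 3 `Clc1ccc(OCc2cn(C(c3ccccc3)c3ccccc3)nn2)cc1` gives 13400 nM.

Compound 3 holds the lowest number of the three, but its standing is mixed: against compound 1 the numbers sit within the scatter a 1.0-fold lower number from compound 1 to compound 3 (0.00 log units; within the scatter), and only against compound 2 does it separate a 2.3-fold lower number from compound 2 to compound 3 (0.37 log units; beyond the scatter). Compound 1 and compound 2 themselves differ by a modest step of a 2.3-fold higher number from compound 1 to compound 2 (0.37 log units; beyond the scatter).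

The next compound, compound 4 `Cc1ccc(OCc2cn(C(c3ccccc3)c3ccccc3)nn2)cc1`, differs from compound 3 by methyl in place of chloro on an aromatic carbon.

Among the compounds with values here, the only measured step that touches this position is the one from compound 2 to compound 3 a 2.3-fold lower number from compound 2 to compound 3 (0.37 log units; beyond the scatter), where adding chloro gave a modest improvement. Nothing shows what methyl does at the same position; it may sit anywhere between hydrogen and chloro, or match either. The honest expectation for compound 4 in this assay is therefore a small move, if any, towards a higher number, and likely within the scatter: an estimated step of a 1.3-fold higher number from compound 3 to compound 4 (0.13 log units; within the scatter).

Compound 4 is accordingly expected at about 18000 nM, with a range of 9000 nM to 40000 nM.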

Compound 4, half-maximal inhibitory concentration: 26800 nM
Compound 4: middle estimate off by 1.5-fold (0.17 log units), on the low side, within the range that was stated.
By their numbers in this assay, from the lowest: compounds 3, 1, 4 and 2 (each within the scatter of the next, the first and the last beyond it).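

In this assay, methyl on this aromatic carbon, para to a large group, does not separate from chloro (a 2.0-fold higher number from compound 3 to compound 4 (0.30 log units; within the scatter)) or from hydrogen (a 1.2-fold lower number from compound 2 to compound 4 (0.07 log units; within the scatter)). Within the data shown here, the only step at this position that lies beyond the scatter therefore remains hydrogen to chloro (a 2.3-fold lower number from compound 2 to compound 3 (0.37 log units; beyond the scatter)), and the methyl compound cannot be placed with either end of that step. Among these compounds, replacing nonyl with 4-methylphenoxy also stays within the scatter (a 2.0-fold higher number from compound 1 to compound 4 (0.30 log units; within the scatter)), as does replacing it with 4-chlorophenoxy (a 1.0-fold lower number from compound 1 to compound 3 (0.00 log units; within the scatter)), whereas the phenoxy replacement lies beyond it (a 2.3-fold higher number from compound 1 to compound 2 (0.37 log units; beyond the scatter)), so of these three replacements only the one without a substituent on the ring separates from nonyl.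

Still open, from the compounds shown here alone, is whether another group at this position, such as methoxy, trifluoromethyl, bromo, an amine or a carboxylic acid, would separate clearly from both hydrogen and chloro, and whether the chloro step holds on a longer chain than the one linking the phenoxy oxygen to the shared core. No evidence is available here that bears on why these groups read as they do.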